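Swapping the Urea Aryl Group on a Glioblastoma Antiproliferative

This account rests on a few compounds, and the source may have more. Where it says the series, first, only, none or still open, it means among the compounds named here.

Three compounds have been measured in a functional assay on GBM1 cells (Homo sapiens) for antiproliferative activity, read by WST assay, with a stated time of 72 h; on this read-out higher numbers stand for weaker inhibition and lower numbers for stronger inhibition:

Compound 1 `O=C(Nc1cccc(F)c1)Nc1cc2ncncc2cc1OCc1cccc(Cl)c1`: 3700 nM
Compound 2 `O=C(Nc1ccc(Cl)c(Cl)c1)Nc1cc2ncncc2cc1OCc1cccc(F)c1`: 2100 nM
Compound 3 `O=C(Nc1ccc(Cl)c(Cl)c1)Nc1cc2ncncc2cc1OCc1ccccc1F`: 4100 nM

Compound 1 differs from compound 2 and from compound 3 by no more than the usual scatter, so the three numbers cannot be told apart with confidence. Going by the values given here, the only single-point step among them, a 2.0-fold higher number from compound 2 to compound 3 (0.29 log units; within the scatter), concerns the fluorine on the benzyl ether and says nothing about the aryl group on the urea nitrogen. Compound 1 and compound 2 differ at two places at once, so no clean step can be read from that pair.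

Compound 4 `O=C(Nc1ccc(C(F)(F)F)cc1)Nc1cc2ncncc2cc1OCc1cccc(Cl)c1` keeps the shared core and the benzyl ether of compound 1 and changes only the urea aryl: 4-(trifluoromethyl)phenyl in place of 3-fluorophenyl on an amide-type nitrogen. Among the compounds with values here, no measured pair tests this change, so the expectation rests on the observation that the aryl changes seen so far moved the number by no more than the scatter. On that basis the expected step is a 1.1-fold lower number from compound 1 to compound 4 (0.02 log units; within the scatter), no larger than the scatter in either direction. Compound 4 is therefore estimated at 3500 nM, with a range from 1200 nM to 10000 nM.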

Compound 4, half-maximal inhibitory concentration: 3400 nM
Beside the measured number, compound 4's estimate is 1.0-fold (0.01 log units) above it; low and high end bracket the measured number.
By their numbers in this assay, from the lowest: compounds 2, 4, 1 and 3 (each within the scatter of the next).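

In this assay, the step of a 1.1-fold lower number from compound 1 to compound 4 (0.04 log units; within the scatter) is the only change shown that touches the aryl group on the urea nitrogen and nothing else, so this position can now be read directly for the first time. Going by these compounds alone, the earlier compounds could not show this, since their one readable step concerned the fluorine on the benzyl ether. Here, 3-fluorophenyl with 7 heavy atoms gives way to 4-(trifluoromethyl)phenyl with 10 heavy atoms, and with the shared core and benzyl ether held fixed, the assay does not separate the two groups. No evidence is available to explain this result.

Still open, going by these compounds, is whether an aryl group on this nitrogen carrying an amine or a carboxylic acid, or a saturated alkyl chain in place of the aryl ring, would move the number beyond the scatter. Within the data shown here, also open is whether the same exchange would read the same way with the benzyl ether of compound 2 or compound 3 in place of the one in compound 1.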